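Benzamide in place of acetamide on the triazole aryl

The compounds below may be only part of what the source reports. "The series", "measured", "known", "first", "only" and "open" are said of these compounds alone.

Measured compounds:
- compound 1, `COc1ccc(/C=C\C(=O)O)c(OCc2cn(-c3ccc(NC(C)=O)cc3)nn2)c1CC=C(C)C`: in a functional assay on A549 cells (Homo sapiens) for cytotoxicity, read by MTT assay, with a stated time of 24 h (a lower number here means a stronger inhibitor, a higher number a weaker inhibitor), compound 1 is recorded as "not determined" (no result reported)
- compound 2, `COc1ccccc1-n1cc(COc2c(/C=C\C(=O)O)ccc(OC)c2CC=C(C)C)nn1`: in this assay compound 2 gives 43000 nM

For the measured compounds named here, compound 1 stands without a number in this assay; the only measured point is compound 2, and no step between compound 1 and compound 2 is available, so their pair shows only that one value and one blank. The compound to be measured is compound 3, `COc1ccc(/C=C\C(=O)O)c(OCc2cn(-c3ccc(NC(=O)c4ccccc4)cc3)nn2)c1CC=C(C)C`. It differs from compound 1 in one place: phenyl in place of methyl on a carbonyl carbon. Going by the values given here, with no measured step on record for this kind of change, the expectation for its size has no anchor itself; the working assumption is a small step in this assay, in no fixed direction, within the scatter of repeated measurements. Among the compounds with values here, the estimate for compound 3 in this assay is 40000 nM, expected to fall between 10000 nM and 150000 nM, resting on compound 2 alone because its value 43000 nM is the only number the series provides.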

Compound 3, half-maximal inhibitory concentration: 42700 nM
The estimate for compound 3 lay 1.1-fold (0.03 log units) below the measured number; low and high end bracket the measured number.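

No step can be read from compound 1 to compound 3 in this assay, where compound 3 gives 42700 nM. The compounds shown leave open how the change from acetamido to benzamido on the shared core bears on this read-out. Nothing further on hand bears on this result.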